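Trimming a Butyl Chain: What to Expect for Compound 3

This account rests on a few compounds, and the source may have more. Where it says the series, first, only, none or still open, it means among the compounds named here.

Of the compounds shown here, two share a small core and have been tested in a functional assay on MCF7 cells (Homo sapiens) for inhibition; a lower number here means a stronger inhibitor, a higher number a weaker inhibitor. Compound 1 `CCCCNC(=O)N1CC1C#N` carries a butyl chain on its urea nitrogen. In this assay, as far as these compounds go, compound 1 gives > 12000 nM, and this value is a limit of the assay rather than a number, so compound 1 stands at the limit of > 12000 nM in this assay, at which 1 of the 2 values shown sits, and its true potency is unknown beyond that. Compound 2 `N#CC1CN1C(=O)Nc1ccc(Cl)cc1Cl`, which bears a dichlorophenyl group instead, gives 900 nM in this assay. Compound 3 `CCNC(=O)N1CC1C#N` is not yet measured; it differs from compound 1 by hydrogen in place of ethyl on a saturated chain carbon, two bonds along the chain from an amide-type nitrogen. Compound 1 already sits at the limit, and the change to a shorter alkyl chain is a small one, so the step that the limit leaves unreadable from compound 1 to compound 3 is expected to remain within the scatter. Compound 3 is therefore expected to give about 20000 nM, most likely again reported only as a limit, within a range from 8000 nM to 50000 nM.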

Compound 3, half-maximal inhibitory concentration: 29000 nM
The estimate for compound 3 lay 1.5-fold (0.16 log units) below the measured number; the measured number falls inside the stated range.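

The result gives no readable step between compound 1 and compound 3, because compound 1 is known only as a limit in this assay: the limit of > 12000 nM in this assay, at which 1 of the 3 values shown sits.

The compounds shown leave open how much going from butyl to ethyl on the shared core changes potency.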